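Two Weak Inhibitors and a Hydroxy Swap

The source may hold more compounds than are shown below. What is called first, only, known or untested is meant among the compounds shown, and "the series" means these compounds.

compound 1 `COc1cc(OC)c(OC)cc1/C=C/C(=O)c1cc(OC(C)=O)ccc1OC(C)=O`: 78500 nM
compound 2 `COc1cc(OC)c(OC)cc1/C=C/C(=O)c1ccc(-c2c[nH]cn2)cc1`: > 150000 nM (a limit)

Both compounds were tested in a functional assay on SW982 cells (Homo sapiens) for inhibition, read by MTT assay, with a stated time of 72 h; a higher number here means a weaker inhibitor, a lower number a stronger inhibitor. There, compound 2 gives > 150000 nM, which is a limit of the assay and not a number. Compound 3 `COc1cc(OC)c(OC)cc1/C=C/C(=O)c1ccc(O)cc1` keeps the shared core but carries hydroxy in place of 1H-imidazol-4-yl on an aromatic carbon, para to a large group: hydroxy in place of 1H-imidazol-4-yl on an aromatic carbon. Among the measured compounds shown here, no step between measured compounds is available to size this change. For the measured compounds named here, the only numerical anchor is compound 1 at 78500 nM, which shares the core, so compound 3 is expected to land in a similar region. The expected change is an at least 3.0-fold lower number from compound 2 to compound 3 (0.47 log units; beyond the scatter), a modest move towards stronger inhibition. Compound 3 is estimated at 50000 nM, with an expected range of 15000 nM to 140000 nM.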

Compound 3, half-maximal inhibitory concentration: 155000 nM
Beside the measured number, compound 3's estimate is 3.1-fold (0.49 log units) below it; the whole stated range lies below it.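

No step can be read from compound 2 to compound 3, because the value of compound 2 is a limit of the assay and not a number: the limit of > 150000 nM in this assay, at which 1 of the 3 values shown sits.

The compounds shown leave open how far hydroxy in place of 1H-imidazol-4-yl actually shifts inhibition, or in which direction.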